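Moving the fluorine from compound 3 to compound 4

A few compounds are considered here, and "the series" means these few. Any claim that something is new, unique, unknown or untested is made for them only; others in the source may bear on it.

Values from a functional assay on OVCAR-5 cells (Homo sapiens) for inhibition, read by CCK-8 assay, with a stated time of 72 h, tested at 1 uM (a lower number here means less inhibition of growth, a higher number more inhibition of growth at the concentration tested), follow
- compound 1 `CN(C)C(=O)c1cc2cnc(Nc3ccc(N)cn3)nc2n1C1CCCC1` gives 12.3%
- compound 2 `CN(C)C(=O)c1cc2cnc(Nc3ccc(NC(=O)C4(C(=O)Nc5ccc(Cl)cc5)CC4)cc3)nc2n1C1CCCC1` gives 8.1%
- compound 3 `CN(C)C(=O)c1cc2cnc(Nc3ccc(NC(=O)C4(C(=O)Nc5cccc(F)c5)CC4)cc3)nc2n1C1CCCC1` gives 26.3%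

Compound 3 stands highest of the three with 26.3% as its number, ahead of compound 1 at 12.3% and compound 2 at 8.1% in that order of closeness. Compound 4 `CN(C)C(=O)c1cc2cnc(Nc3ccc(NC(=O)C4(C(=O)Nc5ccccc5F)CC4)cc3)nc2n1C1CCCC1` has not yet been measured. Its change from compound 3 reads 2-fluorophenyl in place of 3-fluorophenyl on an amide-type nitrogen. Among the compounds with values here, one measured step bears on this, namely a number 18.2 percentage points higher from compound 2 to compound 3 (beyond the scatter) at the same nitrogen. Within the data shown here, that step exchanged the halogen as well as its place, so no measured step shows the fluorine moving alone. Compound 3 also sits at the top of a very small set, so a slight drop in this assay is expected rather than a gain. The estimated change is a number 5.3 percentage points lower from compound 3 to compound 4 (within the scatter) as a small expected step. For compound 4 the expected value is 21% with an estimated range from 8% to 38% as the likely span.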

Compound 4, percent growth inhibition at one concentration: 58%
The estimate for compound 4 lay 37 percentage points below the measured number; measured number outside the range, above it.
By their numbers in this assay, from the lowest: compounds 2 and 1 (each within the scatter of the next); then compound 3; then compound 4.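

In this assay, the place of the fluorine on the phenyl ring mattered on its own: with the same atoms joined differently, 2-fluorophenyl in place of 3-fluorophenyl on the amide-type nitrogen gave a number 31.7 percentage points higher from compound 3 to compound 4 (beyond the scatter) with nothing else altered. The earlier step had changed the halogen and its place together, whereas this one separates out the place, and the wider exchange of 4-chlorophenyl for 2-fluorophenyl gave a number 49.9 percentage points higher from compound 2 to compound 4 (beyond the scatter) at the same nitrogen. No measurement available here accounts for this gain.

The compounds shown leave open whether the gain is specific to fluorine or would persist with 2-chlorophenyl, 2-methylphenyl or 2-methoxyphenyl on that nitrogen. They also leave open whether a 2,6-difluorophenyl group would raise the number further or lower it.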